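This account rests on a few compounds, and the source may have more. Where it says the series, first, only, none or still open, it means among the compounds named here.

Measured in a functional assay on the whole organism for agonist activity, with Mus musculus as the target; a lower number here means that less compound is needed, a higher number that more compound is needed for the effect:
- compound 1 `CC(=O)N(C)CC#CCn1cncc1C` gives 5.4 mg/kg
- compound 2 `CCOC(=O)N(C)CC#CCn1ccnc1` gives > 100 mg/kg

For compound 2, the entry > 100 mg/kg is a limit and not a number, so its position in this assay has no upper bound. Compound 3 `CCOC(=O)N(C)CC#CCn1cncc1C` differs from compound 2 by methyl in place of hydrogen on an aromatic carbon. For the measured compounds named here, no measured step shows this change, so the expectation is loose: a move to a lower dose, of uncertain size, with compound 1 at 5.4 mg/kg as the only numeric reference. The expected change is an at least 2.8-fold lower number from compound 2 to compound 3 (0.45 log units; beyond the scatter). The estimated value for compound 3 is 35 mg/kg, within an expected range of 8 mg/kg to 150 mg/kg.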

Compound 3, dose for half-maximal effect: 97 mg/kg
Compound 3: the middle estimate sits 2.8-fold (0.44 log units) below what was measured, and the stated range covers the measured number.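

In this assay, with ethoxy on the carbonyl carbon, methyl in place of hydrogen on the aromatic carbon gives an at least 1.0-fold lower number from compound 2 to compound 3 (0.01 log units; that floor lies within the scatter), so the size of this change remains unresolved. Compound 2 carries a limit and not a number: the limit of > 100 mg/kg in this assay, at which 1 of the 3 values shown sits. With the ring methyl kept, the group on the carbonyl carbon has a clear effect, as ethoxy in place of methyl gives an 18-fold higher number from compound 1 to compound 3 (1.25 log units; beyond the scatter).

From the compounds shown here alone, the true size of the ring methyl step remains open. So does how an amine or a longer chain such as propoxy on the carbonyl carbon would read in this assay.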